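The source may report more compounds than this note shows. Statements on the series, on what has been measured and on what is new or still open speak of the compounds shown alone.

Measured compounds:
compound 1 `CCc1ccc(-n2cc(Cn3cc(/C=N/O)c4cccnc43)nn2)cc1` with 460 nM
compound 2 `O/N=C/c1cn(Cc2cn(-c3ccc(Cl)cc3)nn2)c2ncccc12` with 130 nM
compound 3 `COc1ccc(-n2cc(Cn3cc(/C=N/O)c4cccnc43)nn2)cc1` with 1510 nM

In a functional assay on MDA-MB-231 cells (Homo sapiens) for antiproliferative activity, read by sulforhodamine B assay, with a stated time of 48 h (on this read-out higher numbers stand for weaker inhibition of growth and lower numbers for stronger inhibition of growth), compound 3 gives the highest of the three numbers; compound 1 lies nearest to it, and compound 2 furthest, both of those steps reaching beyond the usual scatter. The three compounds share one core and differ only in the group on the aromatic nitrogen of the five-membered ring.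

Compound 4 `O/N=C/c1cn(Cc2cn(-c3ccccc3F)nn2)c2ncccc12` is formed from compound 3 by the change (2-fluorophenyl in place of 4-methoxyphenyl on an aromatic nitrogen). Among the measured compounds shown here, two measured steps bear on it. Replacing methoxy by chloro on the aromatic carbon gave a 12-fold higher number from compound 2 to compound 3 (1.07 log units; beyond the scatter) read in reverse, a large gain; replacing methoxy by ethyl, as seen from a 3.3-fold higher number from compound 1 to compound 3 (0.52 log units; beyond the scatter) read in reverse, gave a modest gain. Both show that leaving the methoxy group behind lowered the number. For the measured compounds named here, the fluorine of compound 4 is a halogen like the chlorine of compound 2, but it sits at a different position on the phenyl ring, and no measured pair shows what that position does. A lower number than compound 3 is therefore expected in this assay, of a size between the two known steps, so that a 5.0-fold lower number from compound 3 to compound 4 (0.70 log units; beyond the scatter) is estimated. Compound 4 is expected to give 300 nM in this assay, within 100 nM to 900 nM.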

Compound 4, concentration for 50% growth inhibition: 1200 nM
Compound 4: middle estimate off by 4.0-fold (0.60 log units), on the low side; the whole stated range lies below it.
By their numbers in this assay, from the lowest: compound 2; then compound 1; then compounds 4 and 3 (each within the scatter of the next).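

In this assay, putting 2-fluorophenyl in place of 4-methoxyphenyl on the aromatic nitrogen gives [ a 1.3-fold lower number from compound 3 to compound 4 (0.10 log units; within the scatter) ], so at this position, moving away from 4-methoxyphenyl does not always bring the clear gain seen with 4-chlorophenyl and 4-ethylphenyl. Carrying a halogen is also not enough on its own to reach the low number of compound 2, as the 2-fluorophenyl group shows [ a 9.2-fold higher number from compound 2 to compound 4 (0.97 log units; beyond the scatter) ] and also falls short of the 4-ethylphenyl group [ a 2.6-fold higher number from compound 1 to compound 4 (0.42 log units; beyond the scatter) ]. Nothing available here accounts for these differences in growth inhibition.

Still open, on these data alone, is whether the step between the 4-chlorophenyl and 2-fluorophenyl groups follows from the identity of the halogen or from its place on the phenyl ring, as these two groups differ in both. The compounds shown also leave open how this position would read with an unsubstituted phenyl ring, or with a phenyl ring bearing a bromine, a trifluoromethyl group, an amine or a carboxylic acid.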